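Enlarging the 1,3-dioxolan-2-yl ring on the shared core

The source may hold more compounds than are shown below. What is called first, only, known or untested is meant among the compounds shown, and "the series" means these compounds.

In a functional assay on HFF cells (Homo sapiens) for cytotoxicity, read by neutral red uptake (on this read-out higher numbers stand for lower toxicity in this test and lower numbers for higher toxicity in this test), compound 1 `COC(OC)c1cn(C2C[C@H](O)[C@@H](CO)O2)c(=O)[nH]c1=O` gives > 300000 nM, which is a limit. Compound 2 `O=c1[nH]c(=O)n(C2C[C@H](O)[C@@H](CO)O2)cc1C1OCCO1` gives > 300000 nM, again a limit. For the measured compounds named here, the series so far sits at the limit of > 300000 nM in this assay, at which 2 of the 2 values shown sit.

Compound 3 `O=c1[nH]c(=O)n(C2C[C@H](O)[C@@H](CO)O2)cc1C1OCCCO1` differs from compound 2 by a group of 6 heavy atoms (4 carbon, 2 oxygen; one six-membered non-aromatic ring with 2 hetero atoms) in place of a group of 5 heavy atoms (3 carbon, 2 oxygen; one five-membered non-aromatic ring with 2 hetero atoms), on an aromatic carbon. Going by the values given here, the one measured step that bears on this, a step that the two limits leave unreadable from compound 1 to compound 2, also changed the group on that aromatic carbon and offers no size. No step beyond the scatter is therefore expected in this assay, and no direction. The expected step is a step that the limit leaves unreadable from compound 2 to compound 3. For compound 3 the estimated value is 350000 nM, with an expected range of 150000 nM to 800000 nM.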

Compound 3, half-maximal cytotoxic concentration: > 300000 nM
Compound 3 gave a limit, no number; the forecaster's own chance of this, stated with the estimate: 85%; the middle value is on the limit's open side.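

No step among compound 1, compound 2 and compound 3 can be read in this assay, as each result is a limit: the limit of > 300000 nM in this assay, at which 3 of the 3 values shown sit.

The compounds shown leave open where the true cytotoxic concentration of each lies, and whether enlarging the ring changes it.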